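The compounds below may be only part of what the source reports. "The series", "measured", "known", "first", "only" and "open" are said of these compounds alone.

Compound 1 `O=C1CNc2nc(Nc3ccccc3)ncc2N1` gives 85400 nM in a functional assay on T47D cells (Homo sapiens) for cytotoxicity, read by MTT assay, with a stated time of 48 h; a higher number here means a weaker inhibitor, a lower number a stronger inhibitor. Compound 2 `O=C1CNc2nc(Nc3ccc(F)cc3)ncc2N1` gives > 100000 nM in this assay, and this is a limit of the assay, not a number. The step of an at least 1.1-fold higher number from compound 1 to compound 2 (0.06 log units; that floor lies within the scatter) is therefore only a floor, as the limit of > 100000 nM in this assay, at which 1 of the 2 values shown sits, shows. Compound 3 `O=C1CNc2nc(Nc3ccc(Cl)cc3)ncc2N1` carries chloro in place of fluoro on an aromatic carbon. Among the measured compounds shown here, the single measured step, which also swapped a group on an aromatic carbon of the same ring, stayed within the scatter, so no shift beyond the scatter is expected in this assay here. Compound 3 is expected at 120000 nM, between 50000 nM and 300000 nM, an expected step that the limit leaves unreadable from compound 2 to compound 3, most likely again reported only as a limit.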

Compound 3, half-maximal inhibitory concentration: 29300 nM
The estimate for compound 3 lay 4.1-fold (0.61 log units) above the measured number; the measured number lies below the stated range.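

At the aromatic carbon para to a large group, chloro is the only one of the two substituents shown with a step from hydrogen that can be read as beyond the scatter: a 2.9-fold lower number from compound 1 to compound 3 (0.46 log units; beyond the scatter) in this assay. Chloro in place of fluoro gives an at least 3.4-fold lower number from compound 2 to compound 3 (0.53 log units; beyond the scatter), so the halogens at this carbon are not interchangeable. This step is a floor only: the limit of > 100000 nM in this assay, at which 1 of the 3 values shown sits.

On these data alone, whether bromo or a methoxy group at this carbon would lower the number further stays open. So does the effect of an amine there.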